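Compound 2 to compound 3: changing the carbonyl substituent

The compounds below may be only part of what the source reports. "The series", "measured", "known", "first", "only" and "open" are said of these compounds alone.

Measured so far in a physicochemical assay for solubility, at pH 6.8; a lower number here means a less soluble compound, a higher number a more soluble compound (compounds and values):
- compound 1 (`C[C@H](NC(=O)CC(F)(F)F)c1ccc(NC(=O)[C@H]2C[C@@H]2c2cccnc2)cc1`): 41000 nM
- compound 2 (`C[C@H](NC(=O)c1ccc(C#N)cc1)c1ccc(NC(=O)[C@H]2C[C@@H]2c2cccnc2)cc1`): 175000 nM

Compound 2 holds the higher of the two numbers, and its gap to compound 1 lies beyond the scatter. Compound 3 (`C[C@H](NC(=O)c1ncccn1)c1ccc(NC(=O)[C@H]2C[C@@H]2c2cccnc2)cc1`) has pyrimidin-2-yl in place of 4-cyanophenyl on a carbonyl carbon. Within the data shown here, one measured step bears on this place, and it is modest: a 4.3-fold higher number from compound 1 to compound 2 (0.63 log units; beyond the scatter). Among the measured compounds shown here, with only that step as a guide, a modest upward step of similar or smaller size is expected in this assay. The estimated change is a 1.5-fold higher number from compound 2 to compound 3 (0.17 log units; within the scatter). The value expected for compound 3 is 260000 nM (estimated range 90000 nM to 700000 nM).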

Compound 3, solubility: 27000 nM
Compound 3: the middle estimate sits 9.6-fold (0.98 log units) above what was measured; measured number below the stated range.
By their numbers in this assay, from the lowest: compounds 3 and 1 (each within the scatter of the next); then compound 2.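

In this assay, the carbonyl position responds to which aromatic group it carries, not merely to the presence of one: pyrimidin-2-yl gives a 6.5-fold lower number from compound 2 to compound 3 (0.81 log units; beyond the scatter) in place of 4-cyanophenyl. Against 2,2,2-trifluoroethyl, pyrimidin-2-yl gives a 1.5-fold lower number from compound 1 to compound 3 (0.18 log units; within the scatter) and so does not separate from it, leaving 4-cyanophenyl alone apart from the other two groups. No measurement bearing on the reason for this is available.

Still open, going by these compounds, is whether the nitrile or the carbon-only ring accounts for the number of compound 2. An unsubstituted phenyl on the same carbonyl would separate the two.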